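The source may hold more compounds than are shown below. What is called first, only, known or untested is meant among the compounds shown, and "the series" means these compounds.

Compound 1 `CS(=O)(=O)c1ccc2c(c1)CCN2c1ncnc2c(C3CCN(c4ncccn4)CC3)coc12` and compound 2 `CS(=O)(=O)c1ccc2c(c1)CCN2c1ncnc2c(C3CCN(c4ncc(F)cn4)CC3)coc12` share one core and differ only at a single aromatic carbon. In a functional assay on cells for agonist activity at Glucose-dependent insulinotropic receptor (Homo sapiens), read by a luciferase reporter, with a stated time of 4 h (a higher number here means a larger maximal response, a lower number a smaller maximal response), compound 1 gives 196%, while compound 2 gives 229%, the highest of the two numbers. For the measured compounds named here, the step of a number 33 percentage points higher from compound 1 to compound 2 (beyond the scatter) is the one measured step in this set.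

Compound 3 `COc1cnc(N2CCC(c3coc4c(N5CCc6cc(S(C)(=O)=O)ccc65)ncnc34)CC2)nc1` follows from compound 2 by the change (methoxy in place of fluoro on an aromatic carbon). Going by the values given here, no measured step bears on a methoxy in this position; the one step seen, a number 33 percentage points higher from compound 1 to compound 2 (beyond the scatter), concerns fluoro in place of hydrogen at the same carbon and shows that this carbon tolerates a substituent with a gain in maximal response. Because a fluoro there gave a number 33 percentage points higher from compound 1 to compound 2 (beyond the scatter), a methoxy in its place is expected to keep the response near that of compound 2, with no step beyond the scatter foreseen in either direction, though a small loss cannot be ruled out. Compound 3 is therefore expected to give 220% in this assay, within a range of 180% to 260%, meaning an estimated step of a number 9 percentage points lower from compound 2 to compound 3 (within the scatter).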

Compound 3, largest response reached (Emax), in percent of the reference or control that the assay uses: 186%
Estimate against measurement, compound 3: 34 percentage points above, within the range that was stated.
By their numbers in this assay, from the lowest: compounds 3 and 1 (each within the scatter of the next); then compound 2.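

In this assay, the methoxy group does not keep the gain that fluoro brought at this carbon: the change from 5-fluoropyrimidin-2-yl to 5-methoxypyrimidin-2-yl gives a number 43 percentage points lower from compound 2 to compound 3 (beyond the scatter) and is a large step. The comparison with the unsubstituted ring gives a number 10 percentage points lower from compound 1 to compound 3 (within the scatter), so methoxy leaves the maximal response level with hydrogen, and among these three groups only fluoro stands apart, with a number 33 percentage points higher from compound 1 to compound 2 (beyond the scatter) as its step. For the compounds shown here, this shows that the response at this carbon depends on which substituent is present, something the single step from hydrogen to fluoro could not show, but no measurement here accounts for the difference between fluoro and methoxy.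

Going by these compounds, with only hydrogen, fluoro and methoxy at this carbon, it remains open whether the higher response is particular to fluoro or would also appear with chloro, methyl or nitrile. On these data alone, it is equally open whether a longer chain such as ethoxy, or an amine at the same carbon, would stay level with hydrogen, and whether the same order of groups would hold on another core.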